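Two Weak Nucleosides and a Phenol-Bearing Third

The source may hold more compounds than are shown below. What is called first, only, known or untested is meant among the compounds shown, and "the series" means these compounds.

Compound 1 `OC[C@H]1O[C@@H](n2cnc3c(NCc4ccc(Cl)cc4Cl)ncnc32)[C@H](O)[C@@H]1O` was examined in a functional assay on MCF cells (Homo sapiens) for antiproliferative activity, with a stated time of 72 h (a lower number here means a stronger inhibitor, a higher number a weaker inhibitor), where compound 1 gives 127000 nM. Among the results shown, this is the only value reported as a number. Compound 2 `OC[C@H]1O[C@@H](n2cnc3c(NCc4cc(F)cc(F)c4)ncnc32)C(O)C1O` gives > 166000 nM in this assay, which is a limit of the assay rather than a number. Both compounds thus sit at the weak end of what this assay can resolve, and one of the two values shown is the limit itself (the limit of > 166000 nM in this assay, at which 1 of the 2 values shown sits).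

Compound 3 `Cc1cccc(CNc2ncnc3c2ncn3[C@@H]2O[C@H](CO)[C@@H](O)[C@H]2O)c1O` has not yet been measured. It differs from compound 1 in one place: 2-hydroxy-3-methylphenyl in place of 2,4-dichlorophenyl on a saturated chain carbon bound to a nitrogen on an aromatic ring. Within the data shown here, with no measured step between compounds at hand, the size and direction of the change cannot be read from the data; the shift is expected to be small, from compound 1 to compound 3 estimated at a 1.3-fold higher number from compound 1 to compound 3 (0.10 log units; within the scatter) in this assay, possibly toward the weaker side. Compound 3 is expected to give about 160000 nM in this assay, with a range from 60000 nM to 420000 nM.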

Compound 3, half-maximal inhibitory concentration: 6900 nM
Compound 3: the middle estimate sits 23-fold (1.37 log units) above what was measured; measured number outside the range, below it.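

In this assay, the group on a saturated chain carbon bound to a nitrogen on an aromatic ring turns out to move the read-out well beyond the scatter: replacing 2,4-dichlorophenyl with 2-hydroxy-3-methylphenyl gives an 18-fold lower number from compound 1 to compound 3 (1.26 log units; beyond the scatter). The earlier compounds shown here offered no measured step at this position, and compound 2 remains a limit rather than a number: the limit of > 166000 nM in this assay, at which 1 of the 3 values shown sits. The change replaces the chlorines with a hydroxy and a methyl group and brings in a hydrogen-bond donor and acceptor, so the stronger value of compound 3 goes with this substitution.

The compounds shown do not separate the hydroxy group from the methyl group, so it remains open which of them carries the step. Going by these compounds, it also remains open whether a methoxy group or an amine in place of that hydroxy group would keep the gain.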